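Pyridin-2-yl to phenyl on the shared core

This account rests on a few compounds, and the source may have more. Where it says the series, first, only, none or still open, it means among the compounds named here.

Compound 1 `CCCCCNc1oc2c(C)ncc(CO)c2c1Nc1ccccn1`: 5810 nM
Compound 2 `CCCC(C)Nc1oc2c(C)ncc(CO)c2c1Nc1ccccn1`: 9010 nM
Compound 3 `Cc1ncc(CO)c2c(Nc3ccccn3)c(N[C@@H](C)c3ccccc3)oc12`: 4270 nM

In a functional assay on HEK293 cells for agonist activity at Toll-like receptor 8 (Homo sapiens), read by reporter gene assay (a higher number here means that more compound is needed for the effect, a lower number that less compound is needed), compound 1 stands second highest of the three numbers. Its nearest neighbour is compound 3, with a 1.4-fold lower number from compound 1 to compound 3 (0.13 log units; within the scatter); its furthest is compound 2, with a 1.6-fold higher number from compound 1 to compound 2 (0.19 log units; within the scatter). Within the data shown here, the only step beyond the scatter is a 2.1-fold lower number from compound 2 to compound 3 (0.32 log units; beyond the scatter), a modest one.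

Compound 4 `CCCCCNc1oc2c(C)ncc(CO)c2c1Nc1ccccc1` differs from compound 1 by phenyl in place of pyridin-2-yl on a nitrogen on an aromatic ring. Among the measured compounds shown here, none of the measured steps touches this group; all three vary the pentyl, 1-methylbutyl or 1-phenylethyl substituent, so they give no direct guide, and the expectation rests on compound 1 alone with a wide margin. The expected step is a 1.4-fold higher number from compound 1 to compound 4 (0.14 log units; within the scatter). For compound 4 the estimate is 8000 nM, within 2000 nM to 32000 nM.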

Compound 4, half-maximal effective concentration: 2250 nM
Beside the measured number, compound 4's estimate is 3.6-fold (0.55 log units) above it; the range from low to high includes it.
By their numbers in this assay, from the lowest: compounds 4, 3, 1 and 2 (each within the scatter of the next, the first and the last beyond it).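

In this assay phenyl in place of pyridin-2-yl on a nitrogen on an aromatic ring gives a 2.6-fold lower number from compound 1 to compound 4 (0.41 log units; beyond the scatter) and so shows that this position can move the number beyond the scatter. With pentyl on the other nitrogen, the ring nitrogen of pyridin-2-yl is not required for the effect. No measurement here accounts for the change.

From the compounds shown here alone, whether the step holds with 1-methylbutyl or 1-phenylethyl in place of pentyl stays open. So does the standing of pyridin-3-yl or 4-methoxyphenyl on this nitrogen.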